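A Neopentyl Swap Tested for Cell Permeability

The source may hold more compounds than are shown below. What is called first, only, known or untested is meant among the compounds shown, and "the series" means these compounds.

Three compounds built on one shared core have been run in an ADME assay on Caco-2 cells (Homo sapiens) for permeability, read by LC-MS, in the apical to basolateral direction, with a stated time of 60 min, at pH 6.5; on this read-out higher numbers stand for higher permeability and lower numbers for lower permeability. Compound 1, `O=C(NCc1cc(Cl)ccc1-n1cnnn1)[C@@H]1[C@H]2C[C@H]2CN1C(=O)[C@H](O)CC1CC1`, gives 3.4 10^-6 cm/s. Compound 2, `Cc1cccc([C@@H](O)C(=O)N2N=CC[C@H]2C(=O)NCc2cc(Cl)ccc2-n2cnnn2)c1`, gives 9.7 10^-6 cm/s. Compound 3, `O=C(NCc1cc(Cl)ccc1-n1cnnn1)[C@@H]1[C@@H]2C[C@@H]2CN1C(=O)[C@H](O)Cc1ccccn1`, gives 0.62 10^-6 cm/s. Compound 2 therefore stands highest of the three; its nearest neighbour is compound 1, and compound 3 lies furthest away, both gaps being beyond the usual scatter of such measurements.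

Compound 4, `CC(C)(C)C[C@@H](O)C(=O)N1N=CC[C@H]1C(=O)NCc1cc(Cl)ccc1-n1cnnn1`, has not yet been measured in this assay. It differs from compound 2 in one place: neopentyl in place of 3-methylphenyl on a saturated chain carbon bound to a carbonyl carbon and an oxygen on a saturated carbon. Put plainly, a neopentyl takes the place of the 3-methylphenyl on a saturated chain carbon bound to a carbonyl carbon and an oxygen on a saturated carbon, so a six-membered aromatic ring of carbon only gives way to a group with no ring.

For the measured compounds named here, no measured pair shows this exchange, so the expectation rests on compound 2 alone. A step from compound 2 to compound 4 of a 1.4-fold lower number from compound 2 to compound 4 (0.14 log units; within the scatter) is expected, which would sit within the scatter rather than beyond it. Compound 4 is accordingly estimated at 7 10^-6 cm/s, with a likely range from 3.5 10^-6 cm/s to 14 10^-6 cm/s.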

Compound 4, apparent permeability: 24 10^-6 cm/s
For compound 4 the middle estimate is 3.4-fold (0.54 log units) below the measured one; measured number above the stated range.
By their numbers in this assay, from the lowest: compound 3; then compound 1; then compound 2; then compound 4.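

For the compounds shown here, compound 4 gives the first direct reading of a change at this position, on a saturated chain carbon bound to a carbonyl carbon and an oxygen on a saturated carbon, since no two of the earlier compounds differed in only one place. In this assay the exchange of 3-methylphenyl for neopentyl gives a 2.5-fold higher number from compound 2 to compound 4 (0.39 log units; beyond the scatter) and so shows that a six-membered aromatic ring of carbon only is not needed here for a high number: a group with no ring, and fewer heavy atoms, reaches a number that is modestly higher, by a step beyond the usual scatter. Nothing in the data shown explains why the number rose.

On these data alone, a single pair cannot separate the loss of the aromatic ring from the particular shape of neopentyl, and that question stays open until the same carbon is seen carrying an unbranched pentyl chain or a cyclohexyl ring. As far as these compounds go, how this position responds to a group of another kind, such as an amine or a carboxylic acid, also remains open.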